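A few compounds are considered here, and "the series" means these few. Any claim that something is new, unique, unknown or untested is made for them only; others in the source may bear on it.

In a functional assay on A549 cells (Homo sapiens) for antiproliferative activity, read by MTT assay, with a stated time of 72 h (on this read-out lower numbers stand for stronger inhibition and higher numbers for weaker inhibition), the compounds share one core and differ in the group on an aromatic nitrogen. Compound 1 `CN1CCN(c2ccc(Nc3ncc4nc(Nc5ccc(F)cc5)n([C@H]5CCCN(S(=O)(=O)C6CC6)C5)c4n3)cc2)CC1`, which carries 1-(cyclopropylsulfonyl)piperidin-3-yl there, gives 1320 nM. Compound 3 `CN1CCN(c2ccc(Nc3ncc4nc(Nc5ccc(F)cc5)n(-c5cccc(NC(=O)CO)c5)c4n3)cc2)CC1`, which carries 3-(((hydroxymethyl)carbonyl)amino)phenyl in that place, gives 1510 nM, so the two stand level within the scatter. Among the compounds with values here, for compound 2 `CN1CCN(c2ccc(Nc3ncc4nc(Nc5ccc(F)cc5)n([C@H]5CCCC(NC(=O)OC(C)(C)C)C5)c4n3)cc2)CC1` the entry reads "not determined" (no result reported), which leaves compound 3 as the only numerical neighbour of compound 1.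

Compound 4 `CN1CCN(c2ccc(Nc3ncc4nc(Nc5ccc(F)cc5)n([C@@H]5CCN(S(=O)(=O)C6CC6)C5)c4n3)cc2)CC1` keeps the core and the cyclopropylsulfonyl group, but 1-(cyclopropylsulfonyl)pyrrolidin-3-yl takes the place of 1-(cyclopropylsulfonyl)piperidin-3-yl: 1-(cyclopropylsulfonyl)pyrrolidin-3-yl in place of 1-(cyclopropylsulfonyl)piperidin-3-yl on an aromatic nitrogen. The change lies on an aromatic nitrogen of a five-membered aromatic ring with 2 nitrogen. Within the data shown here, only one measured step bears on it, and that step exchanges the whole group at the same nitrogen: a 1.1-fold higher number from compound 1 to compound 3 (0.06 log units; within the scatter). Among the measured compounds shown here, no measured pair differs in ring size alone, so this evidence is indirect. Even so, a full exchange of that group stayed within the scatter, and a smaller change is not expected to do more. No direction is favoured. The estimate is a 1.1-fold higher number from compound 1 to compound 4 (0.03 log units; within the scatter), an expected step that stays within the scatter. Compound 4 is expected at 1400 nM, with an estimated range from 600 nM to 3500 nM.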

Compound 4, half-maximal inhibitory concentration: > 10000 nM
Compound 4 ended at the assay's limit; the forecaster's own chance of this, stated with the estimate: 5%; middle value at least 7.1-fold (0.85 log units) from the limit.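

For compound 4, this assay gives a limit and not a number: the limit of > 10000 nM in this assay, at which 1 of the 4 values shown sits.

Even so, the result shows a sensitivity at this aromatic nitrogen that the earlier compounds had not shown: replacing the six-membered non-aromatic ring with the five-membered one while keeping the cyclopropylsulfonyl group gives an at least 7.5-fold higher number from compound 1 to compound 4 (0.87 log units; beyond the scatter), whereas the exchange of the whole group gave only a 1.1-fold higher number from compound 1 to compound 3 (0.06 log units; within the scatter). Measured against the other group, 1-(cyclopropylsulfonyl)pyrrolidin-3-yl also gives an at least 6.6-fold higher number from compound 3 to compound 4 (0.82 log units; beyond the scatter), so among these compounds a change within the saturated ring counts for more than the exchange of that ring for a substituted phenyl group.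

The compounds shown leave open whether the result belongs to ring size alone or also depends on the arrangement at the defined stereocentre, since a single pair cannot separate the two. They also leave open whether the pyrrolidine ring would give a similar result with an acetyl group or a free amine in place of the cyclopropylsulfonyl group.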